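Allyloxy in place of 1H-pyrazol-1-yl: working notes

The source may report more compounds than this note shows. Statements on the series, on what has been measured and on what is new or still open speak of the compounds shown alone.

compound 1 `Cc1cc(-n2cccn2)cc(C(=O)NNS(=O)(=O)c2ccccc2)c1F`: 0.05 h
compound 2 `Cc1cc(OC(C)C)cc(C(=O)NNS(=O)(=O)c2ccccc2F)c1`: < 0.0334 h (a limit)

For the measured compounds named here, in an ADME assay on microsomes from liver (Mus musculus) for metabolic stability, read by HPLC, using NADPH, with a stated time of 60 min, tested at 1 uM, in the presence of a further agent that is not named here (a higher number here means that the compound lasts longer, a lower number that the compound disappears faster), compound 1 gives 0.05 h, the only actual number so far. Compound 2 gives < 0.0334 h, which is a limit of the assay. Compound 3 `C=CCOc1cc(C)c(F)c(C(=O)NNS(=O)(=O)c2ccccc2)c1` carries allyloxy in place of 1H-pyrazol-1-yl on an aromatic carbon of the shared core (allyloxy in place of 1H-pyrazol-1-yl on an aromatic carbon). Going by the values given here, no measured step covers this change, and the expected 1.3-fold lower number from compound 1 to compound 3 (0.10 log units; within the scatter) stays within the usual scatter, with no firm direction. In this assay the estimated value for compound 3 is 0.04 h, with an expected range from 0.025 h to 0.08 h.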

Compound 3, half-life: < 0.0334 h
Compound 3 was reported as a limit (the forecaster's own chance of this, stated with the estimate: 45%); middle value at least 1.1-fold (0.07 log units) from the limit.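

On this aromatic carbon, compound 3 gives < 0.0334 h in this assay as a limit of the assay, not a number. Allyloxy in place of 1H-pyrazol-1-yl therefore reads only as an at least 1.4-fold lower number from compound 1 to compound 3 (0.17 log units; that floor lies within the scatter) and the full size of the step stays unknown. Only a floor can be stated for this change, and compound 3 sits at the same limit as compound 2: the limit of < 0.0334 h in this assay, at which 2 of the 3 values shown sit.

From the compounds shown here alone, whether an amine, a carboxylic acid or a longer alkoxy chain on this carbon would give a half-life clear of that limit in this assay stays open.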